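Fluorine on the phenyl ring of a histamine antagonist

This account rests on a few compounds, and the source may have more. Where it says the series, first, only, none or still open, it means among the compounds named here.

Compound 1 `N=C(NCCCc1c[nH]cn1)NCCCC(c1ccc(F)cc1)c1ccccn1`: 46.8 nM
Compound 2 `N=C(NCCCc1c[nH]cn1)NCCC(c1ccccc1)c1ccccn1`: 97.7 nM
Compound 3 `N=C(NCCCc1c[nH]cn1)NCCC(c1ccc(F)cc1)c1ccccn1`: 22.4 nM

In a functional assay on ileum for antagonist activity at histamine H1 receptor (Cavia porcellus) (a lower number here means tighter binding, a higher number weaker binding), compound 2 gives the highest number of the three. Compound 1 gives 46.8 nM with one more link in the chain to the phenyl, and the change a 4.4-fold lower number from compound 2 to compound 3 (0.64 log units; beyond the scatter) shows what a fluoro on the ring did in the same chain length.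

Compound 4 `N=C(NCCCc1c[nH]cn1)NCCC(c1cccc(F)c1)c1ccccn1` differs from compound 2 by fluoro in place of hydrogen on an aromatic carbon. Within the data shown here, only the step from compound 2 to compound 3 bears on it, the same change cut one place further round the ring; that step was modest and beyond the scatter. A lower number is therefore expected for compound 4, though perhaps not by as much. Compound 4 is estimated at 55 nM (20 nM to 150 nM), an expected step of a 1.8-fold lower number from compound 2 to compound 4 (0.25 log units; within the scatter).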

Compound 4, dissociation constant: 158 nM
Beside the measured number, compound 4's estimate is 2.9-fold (0.46 log units) below it; measured number outside the range, above it.
By their numbers in this assay, from the lowest: compound 3; then compound 1; then compounds 2 and 4 (each within the scatter of the next).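

In this assay the result a 1.6-fold higher number from compound 2 to compound 4 (0.21 log units; within the scatter) stays within the scatter, so phenyl to 3-fluorophenyl brings no clear gain, unlike the 4-fluorophenyl of compound 3. Where the fluoro sits on the ring therefore counts, as a 7.1-fold higher number from compound 3 to compound 4 (0.85 log units; beyond the scatter) makes plain for these two isomers. Nothing at hand accounts for this difference.

On these data alone, whether a chloro or a methoxy group at the same place would follow the fluoro stays open. So does how 3-fluorophenyl would behave on the longer chain of compound 1.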